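Variation at one carbonyl carbon of the shared core

The compounds below may be only part of what the source reports. "The series", "measured", "known", "first", "only" and "open" are said of these compounds alone.

The series keeps one core and varies the group on a single carbonyl carbon. Compound 1 `C=CCN(C)C(=O)c1ccc(C(CC)(CC)c2ccc(OCCC(O)(CC)CC)c(C)c2)n1CC` carries allyl(methyl)amino there; in a functional assay on MCF7 cells (Homo sapiens) for antiproliferative activity, read by MTT assay, with a stated time of 48 h (on this read-out lower numbers stand for stronger inhibition and higher numbers for weaker inhibition), compound 1 gives only a limit of the assay, > 50000 nM. Compound 2 `C#CCCOC(=O)c1ccc(C(CC)(CC)c2ccc(OCCC(O)(CC)CC)c(C)c2)n1CC` carries (but-3-yn-1-yl)oxy, and in this assay compound 2 likewise gives a limit, > 50000 nM. Compound 3 `CCn1c(C(=O)Nc2ccc(OC(F)(F)F)cc2)ccc1C(CC)(CC)c1ccc(OCCC(O)(CC)CC)c(C)c1` carries (4-(trifluoromethoxy)phenyl)amino, and in this assay compound 3 also gives a limit, > 50000 nM. Compound 2 thus stands at the limit, as do the other two values shown (the limit of > 50000 nM in this assay, at which 3 of the 3 values shown sit). None of the steps among these three can be read: a step that the two limits leave unreadable from compound 1 to compound 2, a step that the two limits leave unreadable from compound 1 to compound 3 and a step that the two limits leave unreadable from compound 2 to compound 3 all sit between two limits.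

Compound 4 `CCn1c(C(=O)NC(C)C(=O)O)ccc1C(CC)(CC)c1ccc(OCCC(O)(CC)CC)c(C)c1` is not yet measured. It differs from compound 2 by the change ((1-carboxyethyl)amino in place of (but-3-yn-1-yl)oxy on a carbonyl carbon). Within the data shown here, the steps that bear on it, both changing the group on the same carbonyl carbon, are a step that the two limits leave unreadable from compound 1 to compound 2 and a step that the two limits leave unreadable from compound 2 to compound 3; neither yields a size or a direction. No step beyond the scatter can be foreseen from them, and the three limits support only a further limit. The expected step is a number no higher from compound 2 to compound 4 (the limit leaves the size open). For compound 4 in this assay the estimate is 50000 nM, within 20000 nM to 200000 nM, most likely reported as a limit.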

Compound 4, half-maximal inhibitory concentration: 19700 nM
The estimate for compound 4 lay 2.5-fold (0.40 log units) above the measured number, outside the stated range (below it).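

In this assay, this carbonyl carbon now shows a readable effect: (1-carboxyethyl)amino in place of (but-3-yn-1-yl)oxy gives an at least 2.5-fold lower number from compound 2 to compound 4 (0.40 log units; beyond the scatter), the same group in place of allyl(methyl)amino gives an at least 2.5-fold lower number from compound 1 to compound 4 (0.40 log units; beyond the scatter), and 1-carboxyethyl in place of 4-(trifluoromethoxy)phenyl on an amide-type nitrogen gives an at least 2.5-fold lower number from compound 3 to compound 4 (0.40 log units; beyond the scatter). Compound 1 and compound 3 also carry a nitrogen on this carbonyl carbon, so that nitrogen alone does not bring the read-out off the limit; among the compounds shown, only the 1-carboxyethyl substituent does. The three new steps are bounds rather than sizes, and the steps among compound 1, compound 2 and compound 3 cannot be read, because the other values are all limits: the limit of > 50000 nM in this assay, at which 3 of the 4 values shown sit.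

From the compounds shown here alone, whether the carboxylic acid itself is needed remains open, and a methyl ester of the 1-carboxyethyl group would test this directly. Also open, going by these compounds, is how the number responds to the chain, as a carboxymethyl group or a longer carboxylic acid chain on the same nitrogen would show.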